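Swapping the Sulfonyl Substituent: Dimethylamino to Phenyl

The compounds below may be only part of what the source reports. "The series", "measured", "known", "first", "only" and "open" are said of these compounds alone.

Measured so far:
Compound 1, `CC1(C)C=C(n2ccccc2=O)c2cc(S(=O)(=O)N=[N+]=[N-])ccc2O1`, gives 88.3% in a functional assay on the whole organism (aorta) with Rattus norvegicus as the target; on this read-out lower numbers stand for smaller maximal responses and higher numbers for larger maximal responses.
Compound 2, `CC(C)NS(=O)(=O)c1ccc2c(c1)C(n1ccccc1=O)=CC(C)(C)O2`, gives 76.9%.
Compound 3, `CN(C)S(=O)(=O)c1ccc2c(c1)C(n1ccccc1=O)=CC(C)(C)O2`, gives 78.3%.

The three compounds share one core and differ only in the group carried by the sulfonyl sulfur. Compound 3 differs from each of the other two by no more than the usual scatter: a number 10 percentage points lower from compound 1 to compound 3 (within the scatter) and a number 1.4 percentage points higher from compound 2 to compound 3 (within the scatter). Among the measured compounds shown here, the only step that reaches beyond the scatter is a number 11.4 percentage points lower from compound 1 to compound 2 (beyond the scatter), and it is modest.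

Compound 4, `CC1(C)C=C(n2ccccc2=O)c2cc(S(=O)(=O)c3ccccc3)ccc2O1`, takes the next step at the same place: phenyl in place of dimethylamino on a sulfonyl sulfur. For the measured compounds named here, no measured step covers an exchange of an amino group for an aromatic ring on this sulfur, so the expectation rests on the pattern that every change made so far at this position left the maximal response in this assay nearly unchanged, with compound 1 to compound 2 the only exception and that a small one.

Compound 4 is therefore expected to show a number 1.7 percentage points higher from compound 3 to compound 4 (within the scatter), no larger than the scatter. The estimated value for compound 4 is 80%, within a range from 65% to 95%.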

Compound 4, largest response reached (Emax), in percent of the reference or control that the assay uses: 79.3%
The estimate for compound 4 lay 0.7 percentage points above the measured number; measured number inside the range.
By their numbers in this assay, from the lowest: compounds 2, 3, 4 and 1 (each within the scatter of the next, the first and the last beyond it).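

In this assay this position does not depend on a nitrogen-linked group: azido, isopropylamino and dimethylamino all attach through nitrogen, yet phenyl, a six-membered aromatic ring of carbon only, gives a number 1 percentage points higher from compound 3 to compound 4 (within the scatter) when it replaces dimethylamino on the sulfonyl sulfur. Among the compounds shown here, the comparisons with the other two groups read the same way, with a number 2.4 percentage points higher from compound 2 to compound 4 (within the scatter) and a number 9 percentage points lower from compound 1 to compound 4 (within the scatter) on the same read-out, so compound 4 cannot be told apart from any of the three earlier compounds, even though a number 11.4 percentage points lower from compound 1 to compound 2 (beyond the scatter) remains the one step that passes the scatter. Nothing shown explains why so different a group leaves the maximal response within the scatter of the others.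

The compounds shown leave open whether a plain methyl group or a ring amine such as morpholine on the sulfonyl sulfur would also fit this picture, and whether a phenyl ring carrying a methoxy group or a carboxylic acid would. They also leave open how far the maximal response depends on the rest of the shared core, since every compound here keeps it unchanged.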